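Removing the amine-bearing chain from a weak cytotoxic amide

The source may hold more compounds than are shown below. What is called first, only, known or untested is meant among the compounds shown, and "the series" means these compounds.

Three compounds share one core and are compared for how strongly they slow the growth of a cancer cell line, in a functional assay on MDA-MB-435 cells (Homo sapiens) for cytotoxicity, read by MTT assay, with a stated time of 72 h; a higher number here means a weaker inhibitor, a lower number a stronger inhibitor. Compound 1 `N[C@H]1CC[C@H](Nc2c(C(=O)NCc3ccc(F)cc3)nc(N3CCCCS3(=O)=O)c3cccnc23)CC1` gives 5000 nM. Compound 2 `NCCCNc1c(C(=O)NCc2ccc(F)cc2)nc(Br)c2cccnc12` gives 5000 nM, level with compound 1 and together with it the highest of the three numbers. Compound 3 `N[C@H]1CC[C@H](Nc2c(C(=O)NCc3ccc(Oc4ccccc4)cc3)nc(Br)c3cccnc23)CC1` gives 4000 nM, a gap from compound 2 that lies within the scatter, so none of the three can be called the weakest or the strongest.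

Compound 4 `CNc1c(C(=O)NCc2ccc(F)cc2)nc(Br)c2cccnc12` has not yet been tested. It is built from compound 2 by one change: hydrogen in place of 2-aminoethyl on a saturated chain carbon bound to a nitrogen on an aromatic ring. Put differently, the 3-aminopropyl chain becomes a methyl, so the compound keeps its amide and its bromine but loses the chain with its nitrogen.

Among the measured compounds shown here, no measured pair shows this kind of change, so the expectation rests on compound 2 alone, which gives 5000 nM. Shortening the only flexible, nitrogen-carrying arm is expected to cost some potency, a step from compound 2 to compound 4 of a 2.0-fold higher number from compound 2 to compound 4 (0.30 log units; within the scatter) toward a higher number. Compound 4 is thus estimated at 10000 nM, within 3500 nM to 30000 nM, and since the measured numbers already sit high, a limit rather than a number is a real possibility.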

Compound 4, half-maximal inhibitory concentration: > 20000 nM
Compound 4: no number, only a limit; the forecaster's own chance of this, stated with the estimate: 35%; middle value at least 2.0-fold (0.30 log units) away from the limit.
By their numbers in this assay, from the lowest: compounds 3, 1 and 2 (each within the scatter of the next). At a limit, above all of these: compound 4.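

This is the first step among these compounds that changes one place only, and it shows that the group on this nitrogen matters even in a weak series. Cutting the 3-aminopropyl chain back to methyl, with the amide and the bromine kept, gives an at least 4.0-fold higher number from compound 2 to compound 4 (0.60 log units; beyond the scatter), a change that stands clear of the scatter although the three earlier values could not be told apart. In this assay compound 4 gives > 20000 nM, which is a limit and not a number, so the step has a floor but no known size: the limit of > 20000 nM in this assay, at which 1 of the 4 values shown sits.

The compounds shown do not separate the loss of the terminal amine from the loss of chain length. A plain propyl chain would test the first, and a 4-aminobutyl chain would show whether a longer amine-bearing arm goes beyond compound 2.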